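Cytotoxicity notes on an amide series

The source may report more compounds than this note shows. Statements on the series, on what has been measured and on what is new or still open speak of the compounds shown alone.

Compound 1 `Cn1c(-c2ccc(C#N)cc2)cnc1NC(=O)c1ncc[nH]1` gives in a toxicity assay on THP-1 cells (Homo sapiens) for inhibition (a lower number here means that less compound is tolerated, a higher number that more compound is tolerated), only a limit, > 100000 nM. Compound 2 `Cn1c(-c2cccc(C#N)c2)cnc1NC(=O)c1ncc[nH]1` also reaches only a limit in this assay, > 50000 nM. Compound 3 `COc1ccc(-c2cnc(NC(=O)c3ccn[nH]3)n2C)cc1` likewise gives only a limit in this assay, > 100000 nM. Compound 3 therefore stands with compound 1 at the limit of > 100000 nM in this assay, at which 2 of the 3 values shown sit, whereas compound 2 sits at the limit of > 50000 nM in this assay, at which 1 of the 3 values shown sits. For the measured compounds named here, no measured compound differs from another in a single place, so no step size is known. Compound 4 `COc1ccc(-c2cnc(NC(=O)c3cccc(Br)c3)n2C)cc1` differs from compound 3 by 3-bromophenyl in place of 1H-pyrazol-5-yl on a carbonyl carbon. In this assay compound 4 is expected to tolerate somewhat less compound, an estimated step of an at least 2.0-fold lower number from compound 3 to compound 4 (0.30 log units; that floor lies within the scatter), though a limit may again be reported. The expected value for compound 4 is 50000 nM, in the range 12000 nM to 150000 nM.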

Compound 4, half-maximal cytotoxic concentration: > 100000 nM
Compound 4 ended at the assay's limit; the forecaster's own chance of this, stated with the estimate: 45%; middle value at least 2.0-fold (0.30 log units) from the limit.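

Compound 3 and compound 4 both stop at a limit in this assay, so no step can be read between them. The compounds shown leave open where any half-maximal cytotoxic concentration actually lies.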